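A Methyl for Trifluoromethyl Swap on Two Related Scaffolds

A few compounds are considered here, and "the series" means these few. Any claim that something is new, unique, unknown or untested is made for them only; others in the source may bear on it.

The measured compounds:
- Compound 1 `NC(=O)c1c(NC(=O)c2ccc(C(F)(F)F)cc2)sc2c1CCN(C(=O)Nc1ccccc1Cl)C2`: in a functional assay on MKN-74 cells (Homo sapiens) for antiproliferative activity, with a stated time of 24 h (a higher number here means a weaker inhibitor, a lower number a stronger inhibitor), compound 1 gives 43900 nM.
- Compound 2 `Cc1ccc(C(=O)Nc2sc3c(c2C(N)=O)CCN(C(=O)Nc2ccccc2Cl)C3)cc1`: in this assay compound 2 gives 27600 nM.
- Compound 3 `NC(=O)c1c(NC(=O)c2ccccc2Br)sc2c1CCN(C(=S)Nc1ccccc1C(F)(F)F)C2`: in this assay compound 3 gives 24300 nM.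

Compound 1 and compound 2 differ by methyl in place of trifluoromethyl on an aromatic carbon, and this change gave a 1.6-fold lower number from compound 1 to compound 2 (0.20 log units; within the scatter). All three measured values lie within the scatter of one another, so no ordering among them can be read.

Compound 4 `Cc1ccccc1NC(=S)N1CCc2c(sc(NC(=O)c3ccccc3Br)c2C(N)=O)C1` is not yet measured. It differs from compound 3 by methyl in place of trifluoromethyl on an aromatic carbon. Going by the values given here, this is the same kind of change as the one from compound 1 to compound 2, but not the same: there the methyl stands para to a large group, here ortho to a large group. The difference between the core of compound 1 and the core of compound 3 is not broken down here.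

A step of similar, small size is expected, a 1.2-fold lower number from compound 3 to compound 4 (0.08 log units; within the scatter). This rests on the step of a 1.6-fold lower number from compound 1 to compound 2 (0.20 log units; within the scatter), which stayed within the scatter. Compound 4 is therefore estimated at 20000 nM, expected between 8000 nM and 60000 nM.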

Compound 4, half-maximal inhibitory concentration: > 50000 nM
Compound 4 was reported as a limit (the forecaster's own chance of this, stated with the estimate: 15%); middle value at least 2.5-fold (0.39 log units) from the limit.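

In this assay, methyl in place of trifluoromethyl on the core of compound 3 gives an at least 2.0-fold higher number from compound 3 to compound 4 (0.31 log units; beyond the scatter). This step does not match the one on the core of compound 1, so the change cannot be carried from one core to the other with a fixed size: the same change on two cores in this assay, a 1.6-fold lower number (0.20 log units; within the scatter) from compound 1 to compound 2 and an at least 2.0-fold higher number (0.31 log units; beyond the scatter) from compound 3 to compound 4, at least 3.2-fold (0.51 log units) apart, beyond the scatter of two such steps Compound 4 is reported as > 50000 nM, which is a limit of the assay and not a number, so the full size of the step stays unknown, and with only one pair on each core nothing shows which of the differences between the two pairs sets the gap: the limit of > 50000 nM in this assay, at which 1 of the 4 values shown sits.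

The compounds shown leave open how the same change behaves on a third core, or with both pairs carrying it in the same place on the ring. They also leave open whether another group in place of the trifluoromethyl, such as a methoxy group or a nitrile, would keep the number of compound 3 or move it as methyl does.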